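A few compounds are considered here, and "the series" means these few. Any claim that something is new, unique, unknown or untested is made for them only; others in the source may bear on it.

Compound 1 `CCCN1C(=O)[C@@H](NC(=O)c2cccc(C)c2)[C@@H](c2ccc(F)cc2)c2c1nn(CCC)c2C`: > 25000 nM
Compound 2 `CCN1C(=O)[C@@H](NC(=O)c2cccc(C)c2)[C@@H](c2ccc(F)cc2)c2c(C)nn(C3CC3)c21`: > 25000 nM
Compound 3 `Cc1ccc([C@H]2c3c(C)nn(-c4ccccc4)c3NC(=O)[C@H]2NC(=O)c2cccc(C)c2)cc1`: > 25000 nM

These three compounds share a similar build, and each has been tested for its effect on cells. In an ADME assay on HCC95 cells (Homo sapiens) for inhibition, read by CellTiter-Glo, with a stated time of 72 h (on this read-out higher numbers stand for an effect only at larger amounts of compound and lower numbers for an effect already at smaller amounts), compound 2 gives > 25000 nM, which is a limit of the assay and not a number. Compound 2 therefore has no exact position on the scale, and it stands with the other two: the limit of > 25000 nM in this assay, at which 3 of the 3 values shown sit.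

The next compound to be tested is compound 4 `CCN1C(=O)[C@@H](NC(=O)c2cccc(C)c2)[C@@H](c2ccc(F)cc2)c2c(C)nn(-c3ccccc3)c21`. It carries phenyl in place of cyclopropyl on an aromatic nitrogen. Among the measured compounds shown here, no measured pair of compounds differs in just one place, so the data give no direct guide to the size of this change.

Compound 3 also carries phenyl on an aromatic nitrogen, although it differs from compound 4 elsewhere, and compound 3 gives > 25000 nM, again a limit. On that evidence, the expectation in this assay is that compound 4 most likely stays at the limit, with a modest shift towards lower numbers as the alternative. The expected change is an at least 1.6-fold lower number from compound 2 to compound 4 (0.22 log units; that floor lies within the scatter). For compound 4 the estimated value is 15000 nM, with an expected range from 2500 nM to 25000 nM.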

Compound 4, half-maximal effective concentration: > 25000 nM
Compound 4 ended at the assay's limit; the forecaster's own chance of this, stated with the estimate: 60%; middle value at least 1.6-fold (0.22 log units) from the limit.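

In this assay compound 4 gives > 25000 nM, which is a limit of the assay and not a number. Compound 2 sits at the same limit, so no step can be read between compound 2 and compound 4. It remains open whether phenyl and cyclopropyl on the aromatic nitrogen differ at all, and which change to the shared core would give a readable number, since every compound shown sits at one point: the limit of > 25000 nM in this assay, at which 4 of the 4 values shown sit.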